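Notes on the carboxylic acid analogue of compound 3

The compounds below may be only part of what the source reports. "The series", "measured", "known", "first", "only" and "open" are said of these compounds alone.

Compound 3 `COC(=O)c1cccc(CN(CCCCC(N)=O)C[C@H]2O[C@@H](n3cnc4c(N)ncnc43)[C@H](O)[C@@H]2O)c1` stands at the boundary of what an assay on cells for inhibition of Nicotinamide N-methyltransferase (Homo sapiens), with stated times of 10 min and 30 min (a higher number here means a weaker inhibitor, a lower number a stronger inhibitor), can report: in this assay compound 3 gives > 250000 nM, which is a limit of the assay and not a number. Compound 2 `COC(=O)c1cccc(CN(CCCC(N)=O)C[C@H]2O[C@@H](n3cnc4c(N)ncnc43)[C@H](O)[C@@H]2O)c1` returns the same kind of result, as in this assay compound 2 gives > 250000 nM, again a limit. Compound 1 `NC(=O)CCCN(Cc1cccc(C(N)=O)c1)C[C@H]1O[C@@H](n2cnc3c(N)ncnc32)[C@H](O)[C@@H]1O` is no different, and in this assay compound 1 gives > 250000 nM, also a limit. The two steps that join these compounds are therefore not readable in size: a step that the two limits leave unreadable from compound 1 to compound 2 and a step that the two limits leave unreadable from compound 2 to compound 3. All of this rests on (the limit of > 250000 nM in this assay, at which 3 of the 3 values shown sit), so the three compounds cannot be told apart by these numbers.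

Compound 4 `COC(=O)c1cccc(CN(CCCC(=O)O)C[C@H]2O[C@@H](n3cnc4c(N)ncnc43)[C@H](O)[C@@H]2O)c1` differs from compound 3 in a single place: carboxy in place of carbamoylmethyl on a saturated chain carbon, three bonds along the chain from an amine nitrogen. Among the measured compounds shown here, neither measured step bears on this change in a readable way, since each begins and ends at the limit, so no direction of the step can be taken from them. The expectation for compound 4 is accordingly that it stays at or close to the same limit, with an estimated step that the limit leaves unreadable from compound 3 to compound 4. The estimate for compound 4 in this assay is 300000 nM, with a range from 100000 nM to 1000000 nM, and most likely the assay will once more report only a limit.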

Compound 4, half-maximal inhibitory concentration: > 250000 nM
Compound 4 ended at the assay's limit; the forecaster's own chance of this, stated with the estimate: 80%; the middle value is on the limit's open side.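

No new step can be read for compound 4, whether from compound 3 or from compound 2, since both ends of each comparison are limits and not numbers: the limit of > 250000 nM in this assay, at which 4 of the 4 values shown sit. The compounds shown leave open whether any of these single changes shifts inhibition in this assay at all, and in which direction.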